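A few compounds are considered here, and "the series" means these few. Any claim that something is new, unique, unknown or untested is made for them only; others in the source may bear on it.

Among the compounds with values here, in an ADME assay on NPC-TW01 cells (Homo sapiens) for cytotoxicity, read by MTT assay (a lower number here means a stronger inhibitor, a higher number a weaker inhibitor), compound 3 `COc1ccc(/C(COc2cccc3ccccc23)=N/O)cc1` gives 32300 nM, the only actual number among the values shown. Compound 1 `O/N=C(\COc1cccc2ccccc12)c1ccc(Cl)cc1` reads > 50000 nM, which is a limit of the assay. Compound 2 `O/N=C(\COc1cccc2ccccc12)c1ccc(Br)cc1` reads > 50000 nM, likewise a limit.

Compound 4 `O/N=C(\COc1cccc2ccccc12)c1ccc(-c2ccccc2)cc1` has phenyl in place of methoxy on an aromatic carbon, para to a large group: phenyl in place of methoxy on an aromatic carbon. Within the data shown here, no measured step involves phenyl. The nearest steps change the same place: an at least 1.5-fold lower number from compound 1 to compound 3 (0.18 log units; that floor lies within the scatter) and an at least 1.5-fold lower number from compound 2 to compound 3 (0.18 log units; that floor lies within the scatter). The step that the two limits leave unreadable from compound 1 to compound 2 adds nothing readable. No step beyond the scatter is therefore expected in this assay, though a reading at the limit remains possible. The step expected for compound 4 is a 1.1-fold higher number from compound 3 to compound 4 (0.03 log units; within the scatter). Compound 4 is estimated at 35000 nM, with an expected range from 15000 nM to 70000 nM.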

Compound 4, half-maximal inhibitory concentration: > 50000 nM
Compound 4 ended at the assay's limit; the forecaster's own chance of this, stated with the estimate: 45%; middle value at least 1.4-fold (0.15 log units) from the limit.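

In this assay the change to phenyl on this aromatic carbon gives an at least 1.5-fold higher number from compound 3 to compound 4 (0.18 log units; that floor lies within the scatter) and so shows no shift beyond the scatter, even with a whole six-membered aromatic ring entering. Within the data shown here, compound 4 joins compound 1 and compound 2 at a limit of the assay, leaving compound 3 as the only compound with an actual number: the limit of > 50000 nM in this assay, at which 3 of the 4 values shown sit. The steps among compound 1, compound 2 and compound 4 cannot be read, since all three values are limits. As far as these compounds go, whether an amine or a carboxylic acid at this place would give a clearly lower number remains open.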